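The source may report more compounds than this note shows. Statements on the series, on what has been measured and on what is new or still open speak of the compounds shown alone.

Compound 1 `COc1ccc(C2C(C#N)=C(N)OC(c3c[nH]c4ccccc34)=C2C#N)cc1OC` gives 867 ug/mL in a functional assay; a higher number here means a weaker inhibitor, a lower number a stronger inhibitor. Compound 2 `Cc1ccccc1C1C(C#N)=C(N)OC(c2c[nH]c3ccccc23)=C1C#N` reaches only the limit of > 1000 ug/mL in this assay (the limit of > 1000 ug/mL in this assay, at which 1 of the 3 values shown sits). Compound 3 `COc1ccc(C2C(C#N)=C(N)OC(c3c[nH]c4ccccc34)=C2C#N)cc1` gives 859 ug/mL in this assay.

Compound 3 and compound 1 thus sit within the scatter of each other a 1.0-fold lower number from compound 1 to compound 3 (0.00 log units; within the scatter), and compound 2 sets no number. Compound 4 `N#CC1=C(N)OC(c2c[nH]c3ccccc23)=C(C#N)C1c1cccc2ccccc12` differs from compound 3 in one place: naphthalen-1-yl in place of 4-methoxyphenyl on a saturated ring carbon. Two measured steps also exchange the aryl group on that saturated ring carbon, an at least 1.1-fold higher number from compound 1 to compound 2 (0.06 log units; that floor lies within the scatter) and an at least 1.1-fold lower number from compound 2 to compound 3 (0.06 log units; that floor lies within the scatter), and neither moves the number beyond the scatter. The exchange for naphthalen-1-yl is therefore expected to leave compound 4 near compound 3, with a change of a 1.0-fold higher number from compound 3 to compound 4 (0.02 log units; within the scatter) estimated and a fair chance that only a limit is read. Compound 4 is expected to give about 900 ug/mL, in the range 600 ug/mL to 1500 ug/mL.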

Compound 4, half-maximal inhibitory concentration: > 1000 ug/mL
Compound 4: no number, only a limit (the forecaster's own chance of this, stated with the estimate: 35%); middle value at least 1.1-fold (0.04 log units) from the limit.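

In this assay compound 4 gives only a limit, > 1000 ug/mL, as compound 2 does: the limit of > 1000 ug/mL in this assay, at which 2 of the 4 values shown sit. Two six-membered aromatic rings on the saturated ring carbon in place of one bring no number, and the floors of an at least 1.1-fold higher number from compound 3 to compound 4 (0.06 log units; that floor lies within the scatter) and an at least 1.1-fold higher number from compound 1 to compound 4 (0.06 log units; that floor lies within the scatter) leave this exchange, like the earlier ones, without a step beyond the scatter. The step between the two limits cannot be read.

From the compounds shown here alone, how far compound 2 and compound 4 lie past their limits stays open. So does the effect of an aryl group bearing an amine or a carboxylic acid, or of a cyclohexyl group, at this carbon.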